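Swapping an ether for a ketone on the fused ring

The compounds below may be only part of what the source reports. "The series", "measured", "known", "first", "only" and "open" are said of these compounds alone.

The series shares one core and differs at a single position of a six-membered carbon-only aromatic ring that belongs to a fused two-ring system. Compound 2 `CC#C[C@@H](CC(=O)O)c1ccc(OC[C@H]2COc3ccccc3O2)cc1` carries hydrogen there and in a functional assay on HEK293 cells for agonist activity at Free fatty acid receptor 1 (Homo sapiens), read by fluorescence and calcium flux, with a stated time of 10 min (on this read-out lower numbers stand for an effect already at smaller amounts and higher numbers for an effect only at larger amounts of compound), compound 2 gives 90 nM. Compound 3 `CC#C[C@@H](CC(=O)O)c1ccc(OC[C@H]2COc3ccc(OC(C)C)cc3O2)cc1` carries isopropoxy there and in this assay compound 3 gives 280 nM. Compound 1 `CC#C[C@H](CC(=O)O)c1ccc(OC[C@H]2COc3ccc(Cl)cc3O2)cc1`, which differs from the others in more than one place, gives in this assay 3400 nM. Compound 3 therefore stands second highest of the three numbers, nearest to compound 2 and furthest from compound 1.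

The change leading to compound 4 `CC#C[C@@H](CC(=O)O)c1ccc(OC[C@H]2COc3ccc(C(C)=O)cc3O2)cc1` is acetyl in place of isopropoxy on an aromatic carbon. Among the compounds with values here, the only single-place step known is a 3.1-fold higher number from compound 2 to compound 3 (0.49 log units; beyond the scatter), which concerns a different group at the same position and so speaks only indirectly to this change. Given that, a modest change is expected, likely a somewhat higher number, amounting to a 1.4-fold higher number from compound 3 to compound 4 (0.15 log units; within the scatter). Compound 4 is thus estimated at 400 nM, with a range from 120 nM to 1300 nM.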

Compound 4, half-maximal effective concentration: > 30000 nM
Compound 4 was reported as a limit; the forecaster's own chance of this, stated with the estimate: 3%; at least 75-fold (1.87 log units) between middle value and limit.
By their numbers in this assay, from the lowest: compound 2; then compound 3; then compound 1. At a limit, above all of these: compound 4.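

The value of compound 4 is a limit of the assay and not a number: the limit of > 30000 nM in this assay, at which 1 of the 4 values shown sits. The new steps are an at least 100-fold higher number from compound 3 to compound 4 (2.02 log units; beyond the scatter) and an at least 330-fold higher number from compound 2 to compound 4 (2.52 log units; beyond the scatter), both large, whereas a 3.1-fold higher number from compound 2 to compound 3 (0.49 log units; beyond the scatter) is only modest. This position therefore responds very differently to two groups with the same counts of hydrogen-bond donors and acceptors, neither with a ring or a net charge, so those counts alone do not decide the outcome here.

The compounds shown leave open whether the large step belongs to the carbonyl itself or to some other difference between acetyl and isopropoxy. A 1-hydroxyethyl group, an amide or a methoxy group at this position could help to separate these possibilities.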